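Trading chloro for trifluoromethyl in compound 4

A few compounds are considered here, and "the series" means these few. Any claim that something is new, unique, unknown or untested is made for them only; others in the source may bear on it.

In a physicochemical assay for solubility, in simulated intestinal fluid (a lower number here means a less soluble compound, a higher number a more soluble compound), compound 3 `CN(C)CC[C@H](CSc1ccccc1)Nc1ccc(S(=O)(=O)Nc2nc(Cl)nc3c2CCN(C2CCN(Cc4ccccc4-c4ccc(Cl)cc4)CC2)C3)cc1S(=O)(=O)C(F)(F)F` gives 22000 nM, the lowest of three numbers. Compound 1 `CN(C)CC[C@H](CSc1ccccc1)Nc1ccc(S(=O)(=O)Nc2ncnc3c2CCN(C2CCN(Cc4ccccc4-c4ccc(Cl)cc4)CC2)C3)cc1S(=O)(=O)C(F)(F)F` gives 64000 nM, and compound 2 `CN(C)CC[C@H](CSc1ccccc1)Nc1ccc(S(=O)(=O)Nc2ncnc3c2CCN(C2CCN(Cc4cc(F)ccc4-c4ccc(Cl)cc4)CC2)C3=O)cc1S(=O)(=O)C(F)(F)F` gives 63000 nM. Compound 4 `CN(C)CC[C@H](CSc1ccccc1)Nc1ccc(S(=O)(=O)Nc2nc(C(F)(F)F)nc3c2CCN(C2CCN(Cc4ccccc4-c4ccc(Cl)cc4)CC2)C3)cc1S(=O)(=O)C(F)(F)F` is still unmeasured. It carries trifluoromethyl in place of chloro on an aromatic carbon, between two ring nitrogen atoms: trifluoromethyl in place of chloro on an aromatic carbon. Among the compounds with values here, one measured step bears on this carbon: chloro in place of hydrogen gave a 2.9-fold lower number from compound 1 to compound 3 (0.46 log units; beyond the scatter), a modest change beyond the scatter. That step starts from hydrogen rather than chloro, so it is only a loose guide. A small further drop in this assay is expected, probably within the scatter. The estimated step is a 1.4-fold lower number from compound 3 to compound 4 (0.14 log units; within the scatter). Compound 4 is estimated at 16000 nM, with an expected range of 7000 nM to 32000 nM.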

Compound 4, solubility: 36000 nM
Beside the measured number, compound 4's estimate is 2.3-fold (0.35 log units) below it, outside the stated range (above it).
By their numbers in this assay, from the lowest: compounds 3, 4, 2 and 1 (each within the scatter of the next, the first and the last beyond it).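

In this assay, trifluoromethyl in place of chloro on this carbon gives a 1.6-fold higher number from compound 3 to compound 4 (0.21 log units; within the scatter), and trifluoromethyl in place of hydrogen gives a 1.8-fold lower number from compound 1 to compound 4 (0.25 log units; within the scatter). Trifluoromethyl therefore cannot be told apart from either group here, even though chloro and hydrogen themselves are separated by a 2.9-fold lower number from compound 1 to compound 3 (0.46 log units; beyond the scatter). Nothing available explains this result. Going by these compounds, whether an amine, a carboxylic acid or a nitrile on this carbon would shift the number beyond the scatter remains open.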